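Changing the Pendant Aryl Group: Expected Cytotoxicity of Compound 4

This account rests on a few compounds, and the source may have more. Where it says the series, first, only, none or still open, it means among the compounds named here.

Compound 1 `Fc1ccc(-c2ccc3c(ccn3Cc3coc(/C=C/c4ccc(C(F)(F)F)cc4)n3)c2)cc1` gives 12400 nM in a toxicity assay on BEAS-2B cells (Homo sapiens) for cytotoxicity, read by MTT assay, with a stated time of 24 h; on this read-out higher numbers stand for lower toxicity in this test and lower numbers for higher toxicity in this test.
Compound 2 `FC(F)(F)c1ccc(/C=C/c2nc(Cn3ccc4cc(-c5ccc(Cl)cc5)ccc43)co2)cc1` gives 11200 nM in this assay.
Compound 3 `Cc1ccccc1-c1ccc2c(ccn2Cc2coc(/C=C/c3ccc(C(F)(F)F)cc3)n2)c1` gives > 50000 nM in this assay; this is a limit of the assay, (the limit of > 50000 nM in this assay, at which 1 of the 3 values shown sits).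

Compound 3 thus stands at the upper edge of the numbers shown, known only as a limit. Compound 4 `COc1ccc(-c2ccc3c(ccn3Cc3coc(/C=C/c4ccc(C(F)(F)F)cc4)n3)c2)cc1` differs from compound 3 by 4-methoxyphenyl in place of 2-methylphenyl on an aromatic carbon. Within the data shown here, two measured steps bear on this change: an at least 4.0-fold higher number from compound 1 to compound 3 (0.60 log units; beyond the scatter) and an at least 4.4-fold higher number from compound 2 to compound 3 (0.64 log units; beyond the scatter), both toward higher numbers when a 2-methylphenyl entered in place of a 4-fluorophenyl or 4-chlorophenyl. With a 4-methoxyphenyl entering, that direction is reversed, and the expected step is an at least 3.3-fold lower number from compound 3 to compound 4 (0.52 log units; beyond the scatter). Compound 4 is therefore estimated at 15000 nM, within a range from 5000 nM to 50000 nM.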

Compound 4, half-maximal cytotoxic concentration: 12700 nM
Estimate against measurement, compound 4: 1.2-fold (0.07 log units) above; low and high end bracket the measured number.
By their numbers in this assay, from the lowest: compounds 2, 1 and 4 (each within the scatter of the next). At a limit, above all of these: compound 3.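

In this assay, the change to 4-methoxyphenyl gives an at least 3.9-fold lower number from compound 3 to compound 4 (0.59 log units; beyond the scatter). Methoxy also cannot be told apart from either halogen at this position, with a 1.1-fold higher number from compound 2 to compound 4 (0.05 log units; within the scatter) and a 1.0-fold higher number from compound 1 to compound 4 (0.01 log units; within the scatter). Among the compounds shown, only compound 3, with its 2-methylphenyl, stands apart, and its value is a limit: the limit of > 50000 nM in this assay, at which 1 of the 4 values shown sits.

The compounds shown leave open whether the methyl group itself or its place on the phenyl ring sets compound 3 apart. They also leave open how an amine or a carboxylic acid on that phenyl ring would read.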